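Estimating Compound 4 from a Limit and Two Esters

The source may hold more compounds than are shown below. What is called first, only, known or untested is meant among the compounds shown, and "the series" means these compounds.

Compound 1, `C=CC(=C)CC[C@@H]1[C@@]2(C)CCC[C@](C)(COC(=O)/C=C\c3ccc(O)cc3)[C@@H]2CC[C@@]1(C)O`, gives 14100 nM in a functional assay on HL-60 cells (Homo sapiens) for cytotoxicity, read by MTT assay, with a stated time of 48 h; a higher number here means a weaker inhibitor, a lower number a stronger inhibitor. Compound 2, `C=CC(=C)CC[C@@H]1[C@@]2(C)CCC[C@](C)(COC(=O)/C=C/c3ccc(O)cc3)[C@@H]2CC[C@@]1(C)O`, gives 11800 nM in this assay. Compound 3, `C=CC(=C)[C@@H](O)C[C@H]1C(=C)CC[C@@H]2[C@]1(C)CCC[C@]2(C)C(=O)O`, is reported in this assay only as > 40000 nM, which is a limit of the assay and not a number.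

Compounds 1 and 2 carry the same atoms and bonds and differ only in the configuration drawn at one double bond; the step of a 1.2-fold lower number from compound 1 to compound 2 (0.08 log units; within the scatter) is within the scatter, which is expected because of the fact that compounds 1 and 2 differ only in the configuration as drawn. Compound 3 stands apart from both: it sits at the limit of > 40000 nM in this assay, at which 1 of the 3 values shown sits, so no number is known for it, only that it is weaker than that boundary.

Compound 4, `C=C1CC[C@@H]2[C@](C)(CCC[C@]2(C)C(=O)O)[C@H]1C/C=C(\C)C=O`, differs from compound 3 by a group of 5 heavy atoms (4 carbon, 1 oxygen; no ring) in place of a group of 6 heavy atoms (5 carbon, 1 oxygen; no ring), on a saturated chain carbon bound to a saturated ring carbon. Going by the values given here, the one measured step, a change of configuration in the ester side chain of compounds 1 and 2, does not touch the chain that is altered here, so no measured step bears directly on this change, and the starting point itself is a limit. Compound 4 is therefore expected near that boundary, at about 30000 nM, within a range from 8000 nM to 100000 nM. This estimate means a step of an at least 1.3-fold lower number from compound 3 to compound 4 (0.12 log units; that floor lies within the scatter), with a real chance that the assay again reports only a limit.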

Compound 4, half-maximal inhibitory concentration: > 40000 nM
Compound 4: no number, only a limit; the forecaster's own chance of this, stated with the estimate: 50%; at least 1.3-fold (0.12 log units) between middle value and limit.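

In this assay compound 3 is reported only as > 40000 nM, a limit of the assay and not a number. Going by these compounds alone, compound 4 is likewise reported only as > 40000 nM, also a limit, so no step from compound 3 to compound 4 can be read. The compounds shown leave open how strongly either compound acts on these cells, and whether 2-formylprop-1-en-1-yl in place of the larger group changes that at all.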